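Fluoro in place of hydroxy on the shared core

This account rests on a few compounds, and the source may have more. Where it says the series, first, only, none or still open, it means among the compounds named here.

Compound 3 `Oc1ccc2[nH]c(-c3nc(-c4ccccc4)no3)cc2c1` gives 26900 nM in a functional assay on Jurkat cells (Homo sapiens) for antiproliferative activity, read by WST assay, with a stated time of 72 h (a higher number here means a weaker inhibitor, a lower number a stronger inhibitor), and stands highest of the two numbers shown; its nearest neighbour, compound 1 `Cc1noc(-c2cc3cc(F)ccc3[nH]2)n1`, gives 22900 nM in this assay, within the scatter. Compound 2 `COc1ccc2[nH]c(-c3nc(-c4ccccc4)no3)cc2c1` reaches only the assay limit (the limit of > 50000 nM in this assay, at which 1 of the 3 values shown sits), giving > 50000 nM in this assay. For the measured compounds named here, the one measured step, an at least 1.8-fold lower number from compound 2 to compound 3 (0.26 log units; that floor lies within the scatter), rests on that limit. Compound 4 `Fc1ccc2[nH]c(-c3nc(-c4ccccc4)no3)cc2c1` differs from compound 3 by fluoro in place of hydroxy on an aromatic carbon. Going by the values given here, no measured step changes this place on a numbered value, so no shift beyond the scatter is expected for compound 4, and the step of a 1.1-fold lower number from compound 3 to compound 4 (0.03 log units; within the scatter) is estimated as small. Compound 4 is therefore expected to give about 25000 nM in this assay, between 9000 nM and 60000 nM.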

Compound 4, half-maximal inhibitory concentration: 33800 nM
The estimate for compound 4 lay 1.4-fold (0.13 log units) below the measured number; low and high end bracket the measured number.
By their numbers in this assay, from the lowest: compounds 1, 3 and 4 (each within the scatter of the next). At a limit, above all of these: compound 2.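

In this assay, fluoro in place of hydroxy on this aromatic carbon gives a 1.3-fold higher number from compound 3 to compound 4 (0.10 log units; within the scatter), so losing the hydrogen-bond donor and acceptor of hydroxy moves nothing beyond the scatter. Phenyl in place of methyl gives a 1.5-fold higher number from compound 1 to compound 4 (0.17 log units; within the scatter), which likewise does not separate the two compounds. The step of an at least 1.4-fold lower number from compound 2 to compound 4 (0.17 log units; that floor lies within the scatter) rests on a limit and so gives no exact size: the limit of > 50000 nM in this assay, at which 1 of the 4 values shown sits.

On these data alone, whether an amine or a carboxylic acid on this aromatic carbon would shift the number beyond the scatter stays open. So does whether any group here can bring the number far lower.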